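The source may report more compounds than this note shows. Statements on the series, on what has been measured and on what is new or still open speak of the compounds shown alone.

Compound 3 `O=C1/C(=C/c2ccccc2Br)NS(=O)(=O)c2ccccc21` gives 7430 nM in an assay for inhibition of Intestinal-type alkaline phosphatase (Homo sapiens), read by spectrophotometry, with stated times of 10 min and 20 min (a higher number here means a weaker inhibitor, a lower number a stronger inhibitor), and thus has the highest number of the three measured compounds. The parent, compound 1 `O=C1/C(=C/c2ccccc2)NS(=O)(=O)c2ccccc21`, gives 1780 nM, and compound 2 `COc1cccc(/C=C2\NS(=O)(=O)c3ccccc3C2=O)c1`, which carries a methoxy group on an aromatic carbon, gives 1040 nM. The change from compound 3 to compound 4 `O=C1/C(=C/c2cccc(Br)c2)NS(=O)(=O)c2ccccc21` is 3-bromophenyl in place of 2-bromophenyl on a double-bonded chain carbon bound to a double-bonded ring carbon. Among the compounds with values here, no measured step moves a bromine between aromatic carbons; the only step that bears on it is a 4.2-fold higher number from compound 1 to compound 3 (0.62 log units; beyond the scatter), showing that the 2-bromophenyl group itself weakens inhibition relative to the unsubstituted parent. Compound 4 is therefore expected to fall between compound 3 and compound 1, estimated as a 2.7-fold lower number from compound 3 to compound 4 (0.42 log units; beyond the scatter), giving about 2800 nM with a range of 1000 nM to 8000 nM.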

Compound 4, half-maximal inhibitory concentration: 2550 nM
Compound 4: middle estimate off by 1.1-fold (0.04 log units), on the high side; the measured number falls inside the stated range.
By their numbers in this assay, from the lowest: compounds 2, 1 and 4 (each within the scatter of the next, the first and the last beyond it); then compound 3.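

Replacing 2-bromophenyl with 3-bromophenyl changes the reading in this assay (a 2.9-fold lower number from compound 3 to compound 4 (0.46 log units; beyond the scatter)), so where the bromine sits on the phenyl group matters, not merely whether it is present. The 3-bromophenyl compound cannot be told apart from the parent (a 1.4-fold higher number from compound 1 to compound 4 (0.16 log units; within the scatter)), whereas bromo in place of methoxy gives a real difference (a 2.5-fold higher number from compound 2 to compound 4 (0.39 log units; beyond the scatter)). Nothing measured here explains why the two bromophenyl groups differ. The compounds shown leave open how an amine or a carboxylic acid on the phenyl group would read in this assay.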